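The compounds below may be only part of what the source reports. "The series", "measured", "known", "first", "only" and "open" are said of these compounds alone.

Within the data shown here, compound 1 `COc1ccc(Cl)cc1-c1cc(Nc2ccc(Cl)cc2)nc(N)n1` holds the lower of the two numbers so far in an assay on Sf9 cells for inhibition of 1-acyl-sn-glycerol-3-phosphate acyltransferase beta (Homo sapiens); on this read-out lower numbers stand for stronger inhibition and higher numbers for weaker inhibition: compound 1 gives 54 nM, whereas compound 2 `CCOc1ccc(Br)cc1-c1cc(Nc2ccc(C(N)=O)cc2)nc(N)n1` gives 750 nM, a gap beyond the scatter. Compound 3 `Nc1nc(Nc2ccc(Cl)cc2)cc(-c2cc(Cl)ccc2O)n1` differs from compound 1 by hydrogen in place of methyl on an oxygen on an aromatic ring, read one bond further out as methoxy to hydroxy. Among the measured compounds shown here, no measured pair shows this change, so nothing fixes its direction in this assay. A step no larger than the scatter, or a small loss, is expected, and the step of a 1.9-fold higher number from compound 1 to compound 3 (0.27 log units; within the scatter) is estimated accordingly. Compound 3 is thus expected to give 100 nM, within 25 nM to 400 nM.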

Compound 3, half-maximal inhibitory concentration: 10000 nM
Estimate against measurement, compound 3: 100-fold (2.00 log units) below; measured number above the stated range.
By their numbers in this assay, from the lowest: compound 1; then compound 2; then compound 3.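

Among these compounds, the step of a 190-fold higher number from compound 1 to compound 3 (2.27 log units; beyond the scatter) is the first single-place comparison, and it shows that in this assay this position does not tolerate methoxy to hydroxy. Removing the methyl from the oxygen on the aromatic ring is enough on its own to produce a large change. No available data bear on the reason for this step.

From the compounds shown here alone, compound 2 carries ethoxy but differs from compound 1 in more than one place, so how a longer chain behaves here stays open. Going by these compounds, it also remains open how an amine in place of the methoxy would read.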